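Acetyl to Methyl on the Piperazine Nitrogen

The source may report more compounds than this note shows. Statements on the series, on what has been measured and on what is new or still open speak of the compounds shown alone.

Among the measured compounds shown here, compound 2 `CC(=O)N1CCN(C(=O)N2Cc3c(NC(=O)c4ccc(F)cc4)n[nH]c3C2(C)C)CC1` is measured in a functional assay on A2780 cells (Homo sapiens) for antiproliferative activity, read by fluorescence, with a stated time of 72 h (on this read-out higher numbers stand for weaker inhibition and lower numbers for stronger inhibition), only as the limit > 10000 nM, which is a bound of the assay rather than a number; it is the single value at the limit of > 10000 nM in this assay, at which 1 of the 3 values shown sits. For the measured compounds named here, compound 1 `CN1CCC(C(=O)N2Cc3c(NC(=O)c4ccccc4)n[nH]c3C2(C)C)CC1` gives 160 nM in this assay, and compound 3 `CN1CCC(C(=O)N2Cc3c(NC(=O)c4cc(F)cc(F)c4)n[nH]c3C2(C)C)CC1` gives 130 nM; the one measured step, a 1.2-fold lower number from compound 1 to compound 3 (0.09 log units; within the scatter), changes the aromatic ring and not the amine, so no measured step bears directly on the change considered here. Compound 4 `CN1CCN(C(=O)N2Cc3c(NC(=O)c4ccc(F)cc4)n[nH]c3C2(C)C)CC1` differs from compound 2 by methyl in place of acetyl on an amine nitrogen in a ring. Compounds 1 and 3 also carry a methyl on an amine nitrogen in a ring, and both give measured numbers rather than limits. Compound 4 is therefore expected to give 400 nM, between 80 nM and 4000 nM. This estimate means an expected step of an at least 25-fold lower number from compound 2 to compound 4 (1.39 log units; beyond the scatter).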

Compound 4, half-maximal inhibitory concentration: 180 nM
Compound 4: the middle estimate sits 2.2-fold (0.35 log units) above what was measured, and the stated range covers the measured number.
By their numbers in this assay, from the lowest: compounds 3, 1 and 4 (each within the scatter of the next). At a limit, above all of these: compound 2.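

Swapping acetyl for methyl on this amine nitrogen gives an at least 55-fold lower number from compound 2 to compound 4 (1.74 log units; beyond the scatter), so the group at this position can decide whether the compound has measurable activity at all. The earlier step changed only the aromatic ring and did not test this position. Compound 2 is the only compound at a limit of the assay, so the full size of the step remains unknown: the limit of > 10000 nM in this assay, at which 1 of the 4 values shown sits.

The compounds shown do not reveal how an ethyl group or a longer chain ending in a carboxylic acid would behave on this nitrogen. They also leave open whether a free amine, with only hydrogen there, would fall closer to compound 2 or compound 4.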